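This account rests on a few compounds, and the source may have more. Where it says the series, first, only, none or still open, it means among the compounds named here.

Of the compounds shown here, three have been measured so far in a functional assay on MCF7 cells (Homo sapiens) for antiproliferative activity, read by MTT assay, with a stated time of 48 h; on this read-out lower numbers stand for stronger inhibition and higher numbers for weaker inhibition. Compound 1 `N#Cc1ncn(-c2ccc(F)cc2)c1/N=C/c1ccc([N+](=O)[O-])cc1` gives 9100 nM. Compound 2 `N#Cc1ncn(-c2ccc(F)cc2)c1/N=C/c1ccc(O)cc1`, which carries a hydroxy in place of the nitro on an aromatic carbon, gives 11500 nM. Compound 3 `CC(C)c1ccc(/C=N/c2c(C#N)ncn2-c2ccc(F)cc2)cc1`, with an isopropyl in place of the nitro on an aromatic carbon, gives 9870 nM. Compound 1 holds the lowest of these three numbers, but the gaps are small: a 1.3-fold higher number from compound 1 to compound 2 (0.10 log units; within the scatter), a 1.1-fold higher number from compound 1 to compound 3 (0.04 log units; within the scatter), and likewise a 1.2-fold lower number from compound 2 to compound 3 (0.07 log units; within the scatter). On these numbers the three compounds cannot be told apart.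

Compound 4 `N#Cc1ncn(Cc2ccc(F)cc2)c1/N=C/c1ccc([N+](=O)[O-])cc1` is not yet measured. It differs from compound 1 at a different spot: 4-fluorobenzyl in place of 4-fluorophenyl on an aromatic nitrogen. Within the data shown here, none of the measured steps touches the ring nitrogen; all three swap groups on an aromatic carbon of the other ring, and all three stay within the scatter. Among the measured compounds shown here, there is thus no measured step that bears on this change, and nothing in the data points to a direction. The expected step is a 1.1-fold higher number from compound 1 to compound 4 (0.04 log units; within the scatter), with no change beyond the scatter foreseen and a wide range allowed for the lack of guidance. Compound 4 is expected to give 10000 nM, between 3000 nM and 35000 nM.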

Compound 4, half-maximal inhibitory concentration: 10600 nM
For compound 4 the middle estimate is 1.1-fold (0.03 log units) below the measured one; measured number inside the range.
By their numbers in this assay, from the lowest: compounds 1, 3, 4 and 2 (each within the scatter of the next).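

Among these compounds, compound 4 is the first to change the group on the aromatic nitrogen of the five-membered ring; every earlier step swapped a group on an aromatic carbon of the other ring. In this assay, putting 4-fluorobenzyl, with 8 heavy atoms, in place of 4-fluorophenyl, with 7 heavy atoms, gives a 1.2-fold higher number from compound 1 to compound 4 (0.07 log units; within the scatter). The ring nitrogen can therefore carry either group, with the nitro group in place on the other ring, without a change that can be told from the scatter, but no measurement of any other property comes with this result to account for it.

From the compounds shown here alone, it remains open whether a different kind of group on this ring nitrogen, such as a longer chain ending in the same fluorinated ring, a plain ethyl chain or a chain ending in an amine, would move the number beyond the scatter. Also open, going by these compounds, is whether 4-fluorobenzyl behaves the same way with hydroxy or isopropyl on the other ring, and what a carboxylic acid in place of the cyano group would do.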